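Compound 3 to compound 4: a ring change

This account rests on a few compounds, and the source may have more. Where it says the series, first, only, none or still open, it means among the compounds named here.

In a physicochemical assay for lipophilicity, measured as octanol-water partition, at pH 7.4 (on this read-out higher numbers stand for higher lipophilicity and lower numbers for lower lipophilicity), compound 1 `O=C([C@H](O)CS(=O)(=O)c1ccc2cc(Cl)ccc2c1)N1CCC(N2Cc3cccn3C2=O)CC1` gives 2.6 and compound 2 `O=C([C@H](O)CS(=O)(=O)c1ccc2cc(Cl)ccc2c1)N1CCC(N2CCCC2=O)CC1` gives 1.96 while compound 3 `O=C([C@H](O)CS(=O)(=O)c1ccc2cc(Cl)ccc2c1)N1CCC(N2CCOCC2=O)CC1` gives 1.85 on this scale. Compound 3 shares the low end with compound 2 and compound 1 stands apart from both. Compound 4 `O=C([C@H](O)CS(=O)(=O)c1ccc2cc(Cl)ccc2c1)N1CCC(N2CCCCCC2=O)CC1` carries 2-oxoazepan-1-yl in place of 3-oxomorpholin-4-yl on a saturated ring carbon. One ring exchange stayed small (a number 0.11 log units lower from compound 2 to compound 3 (within the scatter)), but the steps away from the group in compound 1 were modest (a number 0.64 log units lower from compound 1 to compound 2 (beyond the scatter); a number 0.75 log units lower from compound 1 to compound 3 (beyond the scatter)). Those steps suggest a rise of similar size, and the expected step is a number 0.60 log units higher from compound 3 to compound 4 (beyond the scatter) in this estimate. For this read-out compound 4 is expected at 2.45 (estimated range 2.05 to 2.85).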

Compound 4, distribution coefficient: 2.52
Beside the measured number, compound 4's estimate is 0.07 log units below it; the measured number falls inside the stated range.
By their numbers in this assay, from the lowest: compounds 3 and 2 (each within the scatter of the next); then compounds 4 and 1 (each within the scatter of the next).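

The earlier compounds shown here paired a high number only with the two-ring group of compound 1, but in this assay the single seven-membered ring of 2-oxoazepan-1-yl reaches the same level, with a number 0.08 log units lower from compound 1 to compound 4 (within the scatter). On this saturated ring carbon, 2-oxopyrrolidin-1-yl and 3-oxomorpholin-4-yl had stayed together, whereas 2-oxoazepan-1-yl separates from both, with a number 0.67 log units higher from compound 3 to compound 4 (beyond the scatter) and a number 0.56 log units higher from compound 2 to compound 4 (beyond the scatter).

As far as these compounds go, whether 2-oxopiperidin-1-yl would sit with compound 2 or with compound 4, and what an amine on the seven-membered ring would do to the number, stays open. Nothing measured here bears on the cause of these steps.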